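A Single Fluorine Added to Compound 1

The source may report more compounds than this note shows. Statements on the series, on what has been measured and on what is new or still open speak of the compounds shown alone.

Compound 1 `COc1nc2ccc(Br)cc2cc1C(c1ccccc1)n1cc(-c2ccccc2)nn1` is the reference point of this set. In an ADME assay on PC-3 cells (Homo sapiens) for cytotoxicity, read by sulforhodamine B assay, with a stated time of 48 h, tested at 10 uM (on this read-out lower numbers stand for less inhibition and higher numbers for more inhibition at the one concentration tested (going by the name of the read-out)), compound 1 gives 5.97%, the lowest of the three numbers measured. Compound 2 `COc1nc2ccc(Br)cc2cc1C(c1ccccc1)n1cc(CCO)nn1` gives 15.5%, and compound 3 `COc1nc2ccc(Br)cc2cc1C(c1ccccc1)n1cc(-c2ccccc2C(F)(F)F)nn1` gives 17.4%. The step of a number 9.5 percentage points higher from compound 1 to compound 2 (within the scatter) lies within the scatter, so no order between compound 1 and compound 2 can be claimed. The step of a number 11.4 percentage points higher from compound 1 to compound 3 (beyond the scatter) lies beyond the scatter, though only modestly, while the step of a number 1.9 percentage points higher from compound 2 to compound 3 (within the scatter) again lies within it.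

Compound 4 `COc1nc2ccc(Br)cc2cc1C(c1ccccc1)n1cc(-c2ccc(F)cc2)nn1` has not yet been measured. It differs from compound 1 by fluoro in place of hydrogen on an aromatic carbon. For the measured compounds named here, the only measured step that touches the same phenyl ring is the one from compound 1 to compound 3, where a trifluoromethyl entered and the number rose modestly beyond the scatter. A fluoro is a far smaller group, and none of the three measured compounds carries one, so nothing in the data indicates more than a small movement. Compound 4 is therefore expected to give about 9%, with a range from 0% to 20%. That estimate means a step of a number 3 percentage points higher from compound 1 to compound 4 (within the scatter), expected to stay within the scatter.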

Compound 4, a percentage reported as inhibition, at one concentration (the size of the read-out at that concentration, not a potency): 16.4%
Compound 4: middle estimate off by 7.4 percentage points, on the low side; the range from low to high includes it.
By their numbers in this assay, from the lowest: compounds 1, 2, 4 and 3 (each within the scatter of the next, the first and the last beyond it).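

In this assay, the step of a number 10.4 percentage points higher from compound 1 to compound 4 (beyond the scatter) shows that adding only fluoro, a single heavy atom para to a large group, is enough to carry the phenyl compound beyond the scatter, though modestly. The trifluoromethyl of compound 3 had shown such a step on this ring, but the step of a number 1 percentage points lower from compound 3 to compound 4 (within the scatter) shows that the far smaller fluoro cannot be separated from it, and the step of a number 0.9 percentage points higher from compound 2 to compound 4 (within the scatter) likewise leaves compound 4 unordered against the 2-hydroxyethyl compound 2. Nothing measured here explains why so small a change on this ring gives this step.

The compounds shown leave open whether a chloro, a nitrile, an amine or a carboxylic acid in the same place on the ring would give a number like that of compound 4 or one closer to that of compound 1. Going by these compounds, every number also comes from a single concentration, so how these compounds compare in potency remains open.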